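The source may hold more compounds than are shown below. What is called first, only, known or untested is meant among the compounds shown, and "the series" means these compounds.

Working notes on the series. The shared core appears in compound 1 `Fc1ccc(-c2cn3nc(Cc4ccc(Cl)cc4)sc3n2)cc1`, compound 2 `Fc1ccc(-c2nc3sc(Cc4ccc(Cl)cc4)nn3c2Br)cc1` and compound 3 `Clc1ccc(Cc2nn3c(Br)c(-c4ccc(Br)cc4)nc3s2)cc1`. In an ADME assay on CCRF-CEM cells (Homo sapiens) for cytotoxicity, with a stated time of 72 h (on this read-out lower numbers stand for stronger inhibition and higher numbers for weaker inhibition), compound 1 gives only a limit of the assay, > 250000 nM. In this assay compound 2 likewise gives only a limit of the assay, > 250000 nM. In this assay compound 3 gives 238000 nM. Between the first two compounds stands a step that the two limits leave unreadable from compound 1 to compound 2, and the next change is an at least 1.0-fold lower number from compound 2 to compound 3 (0.02 log units; that floor lies within the scatter). Compound 2 thus stands at a limit rather than at a number, and the same holds for (the limit of > 250000 nM in this assay, at which 2 of the 3 values shown sit).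

The new compound, compound 4 `N#CSc1c(-c2ccc(F)cc2)nc2sc(Cc3ccc(Cl)cc3)nn12`, differs from compound 2 by cyanosulfanyl in place of bromo on an aromatic carbon. Among the measured compounds shown here, no measured step exchanges bromo for cyanosulfanyl; the only steps touching this part of the core are the unreadable step from compound 1 to compound 2 and the step from compound 2 to compound 3 that lies within the scatter, so nothing points to a move beyond the scatter in this assay in either direction. The expected step is therefore a number no higher from compound 2 to compound 4 (the limit leaves the size open), with a good chance that only a limit is again reported. For compound 4 the estimate in this assay is 250000 nM, with a range from 100000 nM to 600000 nM.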

Compound 4, half-maximal inhibitory concentration: 24000 nM
The estimate for compound 4 lay 10-fold (1.02 log units) above the measured number; measured number below the stated range.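

In this assay, among the compounds shown here, this position on the shared core can carry a change beyond the scatter: cyanosulfanyl in place of bromo gives an at least 10-fold lower number from compound 2 to compound 4 (1.01 log units; beyond the scatter), the first step that is readable as large. Cyanosulfanyl in place of hydrogen at the same aromatic carbon gives an at least 10-fold lower number from compound 1 to compound 4 (1.01 log units; beyond the scatter), so among the compounds shown the lower number goes with cyanosulfanyl and not with the mere presence of a substituent, since bromo gave no readable step from hydrogen. Both sizes are floors and not full measures, because the starting compounds stand at a limit of the assay: the limit of > 250000 nM in this assay, at which 2 of the 4 values shown sit.

The compounds shown do not tell whether the step belongs to the sulfur, to the nitrile or only to the whole cyanosulfanyl group, a question that a methylsulfanyl group or a nitrile alone on this carbon would address. Also open, from the compounds shown here alone, is whether bromo in place of fluoro on the phenyl ring, a change that stays within the scatter when bromo occupies this position, would behave the same way with cyanosulfanyl there.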